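Working notes on a three-member series

A few compounds are considered here, and "the series" means these few. Any claim that something is new, unique, unknown or untested is made for them only; others in the source may bear on it.

Compound 1 `O=S(=O)(NCCNCc1cccc2ccccc12)c1cc(C(F)(F)F)cc(C(F)(F)F)c1` gives 19000 nM in a functional assay on BE(2)-C cells (Homo sapiens) for inhibition, read by MTT assay, with a stated time of 72 h; on this read-out higher numbers stand for weaker inhibition of growth and lower numbers for stronger inhibition of growth.
Compound 2 `O=S(=O)(NCCCNCc1ccccc1Cl)c1cc(C(F)(F)F)cc(C(F)(F)F)c1` gives 15000 nM in this assay.

In this assay compound 2 stands at the low end of the two numbers, though its distance to compound 1 lies within the scatter, so the two are not distinguished. Compound 3 `COc1ccc(CNCCCNS(=O)(=O)c2cc(C(F)(F)F)cc(C(F)(F)F)c2)cc1OC` is not yet measured. It differs from compound 2 by 3,4-dimethoxyphenyl in place of 2-chlorophenyl on a saturated chain carbon bound to an amine nitrogen. Within the data shown here, no measured pair shows this change, so no step size can be read from the data. Compound 3 is expected to stay within the scatter of compound 2, the expected step being a 1.2-fold higher number from compound 2 to compound 3 (0.08 log units; within the scatter). Compound 3 is estimated at 18000 nM, with a range from 6000 nM to 50000 nM.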

Compound 3, concentration for 50% growth inhibition: 3600 nM
Beside the measured number, compound 3's estimate is 5.0-fold (0.70 log units) above it; the whole stated range lies above it.
By their numbers in this assay, from the lowest: compound 3; then compounds 2 and 1 (each within the scatter of the next).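

The aryl group on a saturated chain carbon bound to an amine nitrogen is shown to affect growth inhibition in this assay. Among these compounds, the change to 3,4-dimethoxyphenyl in place of 2-chlorophenyl gives a 4.2-fold lower number from compound 2 to compound 3 (0.62 log units; beyond the scatter) and is the first readable step. No available evidence bears on the reason for this step.

The compounds shown cannot separate loss of the chlorine from gain of the two methoxy groups, as a plain phenyl or a single methoxy group on the ring is absent from them. Steps from compound 1 cannot be read, as it differs from compound 2 and compound 3 in more than one place.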